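An Ethyl Group Added to the Core of Compound 3

The source may report more compounds than this note shows. Statements on the series, on what has been measured and on what is new or still open speak of the compounds shown alone.

Of the compounds shown here, three have been measured in an assay on isolated protein for inhibition of thyroid hormone receptor beta (Homo sapiens), read by fluorescence, with a stated time of 30 min; on this read-out lower numbers stand for stronger inhibition and higher numbers for weaker inhibition. Compound 1 `COc1cc(C(=O)NCc2cccc(Cl)c2)cc2nn(CCn3cccn3)cc12` gives 464 nM in this assay. Compound 2 `CCn1cccc(-c2ccc(N3C[C@H](CNC(=O)c4ccc(Cl)s4)OC3=O)cc2OC)c1=O` gives 61 nM. Compound 3 `CCCN(CC1CCOC1)C(=O)c1ccc2oc(NCc3cccc(Cl)c3)nc2c1` gives 214 nM. Among these three numbers compound 3 holds the second highest; its nearest neighbour is compound 1, whose number is higher by a gap beyond the scatter, while compound 2 lies furthest away with a lower number, also beyond the scatter. Going by the values given here, no two of the three share a single point of difference, so no measured step can be isolated.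

Compound 4 `CCCN(CC1CCOC1)C(=O)c1cc(CC)c2oc(NCc3cccc(Cl)c3)nc2c1` has not yet been measured. It differs from compound 3 in one place: ethyl in place of hydrogen on an aromatic carbon. Among the compounds with values here, with no comparable step among the measured compounds, the direction cannot be read from the data, and the step is expected to be small, possibly not beyond the scatter. The step from compound 3 to compound 4 is estimated at a 1.3-fold lower number from compound 3 to compound 4 (0.13 log units; within the scatter). For compound 4 the expected value in this assay is 160 nM, with a range from 55 nM to 480 nM.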

Compound 4, half-maximal inhibitory concentration: 104 nM
Beside the measured number, compound 4's estimate is 1.5-fold (0.19 log units) above it; low and high end bracket the measured number.
By their numbers in this assay, from the lowest: compounds 2 and 4 (each within the scatter of the next); then compound 3; then compound 1.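

In this assay, ethyl in place of hydrogen on this aromatic carbon gives a 2.1-fold lower number from compound 3 to compound 4 (0.31 log units; beyond the scatter), a modest step and the only one in this set that isolates a single change. Going by these compounds alone, it shows that this carbon of the shared core takes an ethyl group without loss of inhibition, and that the number moves towards stronger inhibition, a direction the earlier compounds could not reveal. Nothing measured here accounts for the lower number.

The compounds shown hold only hydrogen and ethyl at this carbon, so it stays open whether methyl, a longer chain such as propyl, or an amine there would take the number further down or back up. As far as these compounds go, it also stays open whether ethyl would give a similar step with a different amide group on the same core.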